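The compounds below may be only part of what the source reports. "The series", "measured", "known", "first", "only" and "open" are said of these compounds alone.

Compound 3 `O=C(Nc1ccccc1C(F)(F)F)C1CCc2ccccc2N1C(=O)c1ccc(Cl)cc1` serves as the anchor of the set. In a functional assay on NUGC-3 cells (Homo sapiens) for cytotoxicity, read by sulforhodamine B assay, with a stated time of 72 h (on this read-out higher numbers stand for weaker inhibition of growth and lower numbers for stronger inhibition of growth), compound 3 gives 551 nM. Compound 1 `O=C(Nc1ccccc1O)C1CCc2ccccc2N1C(=O)c1ccc(Cl)cc1` differs from it by hydroxy in place of trifluoromethyl on an aromatic carbon; in this assay compound 1 gives 13400 nM, a move of a 24-fold higher number from compound 3 to compound 1 (1.39 log units; beyond the scatter). Compound 2 `CCCCCCCCC(=O)N1c2ccccc2CCC1C(=O)Nc1ccccc1C(F)(F)F` differs from compound 3 in the core by octyl in place of 4-chlorophenyl on a carbonyl carbon; in this assay compound 2 gives 6180 nM, and the step is an 11-fold lower number from compound 2 to compound 3 (1.05 log units; beyond the scatter). Compound 4 `CCCCCCCCC(=O)N1c2ccccc2CCC1C(=O)Nc1ccccc1O` carries the same change on the core of compound 2, namely (hydroxy in place of trifluoromethyl on an aromatic carbon), at a place described in identical words for both pairs. Among the compounds with values here, the only precedent is a 24-fold higher number from compound 3 to compound 1 (1.39 log units; beyond the scatter), measured on a different core, so the transfer is uncertain. Starting from compound 2 at 6180 nM, the step to compound 4 is expected to be a 16-fold higher number from compound 2 to compound 4 (1.21 log units; beyond the scatter). Compound 4 is accordingly estimated at 100000 nM, likely between 30000 nM and 300000 nM, with a real chance that only a limit is reported.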

Compound 4, concentration for 50% growth inhibition: 31100 nM
Beside the measured number, compound 4's estimate is 3.2-fold (0.51 log units) above it; the range from low to high includes it.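

With the octyl chain on the carbonyl, hydroxy in place of trifluoromethyl gives a 5.0-fold higher number from compound 2 to compound 4 (0.70 log units; beyond the scatter) in this assay, the same direction as with 4-chlorophenyl on the carbonyl but a smaller size: the same change on two cores in this assay, a 24-fold higher number (1.39 log units; beyond the scatter) from compound 3 to compound 1 and a 5.0-fold higher number (0.70 log units; beyond the scatter) from compound 2 to compound 4, 4.8-fold (0.68 log units) apart, beyond the scatter of two such steps. With hydroxy on the aromatic carbon, octyl in place of 4-chlorophenyl gives a 2.3-fold higher number from compound 1 to compound 4 (0.37 log units; beyond the scatter), again the direction seen with trifluoromethyl but a smaller size: the same change on two cores in this assay, an 11-fold lower number (1.05 log units; beyond the scatter) from compound 2 to compound 3 and a 2.3-fold lower number (0.37 log units; beyond the scatter) from compound 4 to compound 1, 4.8-fold (0.68 log units) apart, beyond the scatter of two such steps. So the direction of the change carried over between these two cores and its size did not, but a single pair of cores shows neither why the sizes differ nor how the change would read on any other core.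

Still open, going by these compounds, is how an amine or a carboxylic acid would read in place of trifluoromethyl on these two cores. Also open, on these data alone, is whether a longer chain on the carbonyl would keep the same direction.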